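A few compounds are considered here, and "the series" means these few. Any claim that something is new, unique, unknown or untested is made for them only; others in the source may bear on it.

Values in a functional assay for inhibition, with Homo sapiens as the target; a lower number here means a stronger inhibitor, a higher number a weaker inhibitor:
compound 1 `O=C(O)CCCCCn1nc(-c2ccccc2)c(-c2ccccc2)c1-c1ccccc1`: > 78000 nM (a limit)
compound 2 `O=C(O)CCCCCCCn1nc(-c2ccccc2)c(-c2ccccc2)c1-c1ccccc1`: 3400 nM
compound 3 `CNC(=O)CCCCCCCCn1nc(-c2ccccc2)c(-c2ccccc2)c1-c1ccccc1`: > 68000 nM (a limit)

Compound 3 has no numerical value, only the limit > 68000 nM. Compound 4 `N#CCCCCCCCCn1nc(-c2ccccc2)c(-c2ccccc2)c1-c1ccccc1` carries cyano in place of methylcarbamoyl on a saturated chain carbon, eight bonds along the chain from an aromatic nitrogen.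

Going by the values given here, no measured step involves cyano, so the evidence is indirect. The closest comparison is an at least 20-fold higher number from compound 2 to compound 3 (1.30 log units; beyond the scatter), a large step in which (methylcarbamoyl)methyl takes the place of carboxy. Among the compounds with values here, compound 4, like compound 3, has no carboxy group, and compound 2 with 3400 nM is the only compound here with a numerical value. Carboxy alone does not secure that result, as an at least 22-fold lower number from compound 1 to compound 2 (1.36 log units; beyond the scatter) is also large and compound 1 is an acid that stays at a limit. The comparison a step that the two limits leave unreadable from compound 1 to compound 3 cannot be read.

A return towards compound 2 is therefore not expected in this assay, and compound 4 should stay in the weak region near compound 3. The expected step is an at least 1.3-fold lower number from compound 3 to compound 4 (0.13 log units; that floor lies within the scatter), and its size is uncertain given that it starts from a limit. For compound 4 the estimated value is 50000 nM, with an expected range from 10000 nM to 150000 nM.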

Compound 4, half-maximal inhibitory concentration: > 72000 nM
Compound 4 ended at the assay's limit; the forecaster's own chance of this, stated with the estimate: 70%; middle value at least 1.4-fold (0.15 log units) away from the limit.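

In this assay compound 4 gives only > 72000 nM, which is a limit of the assay and not a number. Cyanomethyl in place of carboxy, seven bonds along the chain from an aromatic nitrogen, gives an at least 21-fold higher number from compound 2 to compound 4 (1.32 log units; beyond the scatter), so a second end group without carboxy now falls as far as the measurement can follow, and the earlier drop is no longer tied to methylcarbamoyl alone; the change also removes the amide hydrogen, and no number returns in this assay. The steps that join compound 4 to compound 3 and to compound 1 cannot be read, since both ends of each are limits, so cyano and methylcarbamoyl cannot be ordered here.

Compound 2 remains the only compound with a number, and the compounds shown leave open whether a carboxylic acid on a longer chain than that of compound 2 would hold or improve on it. They also leave open whether any end group other than a carboxylic acid, such as a tetrazole or a primary amide, could give a measurable value on this chain.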